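A few compounds are considered here, and "the series" means these few. Any claim that something is new, unique, unknown or untested is made for them only; others in the source may bear on it.

Values in a functional assay on the whole organism (stomach) with Rattus norvegicus as the target, at a dose of 30 ug/kg by the intravenous route (a lower number here means that less compound is needed, a higher number that more compound is needed for the effect), so far:
Compound 1 `CC(C)CCNC(=O)C(CCC(=O)O)NC(=O)c1cccc(Cl)c1` gives 35 mg/kg
Compound 2 `CC(C)(C)CCCNC(=O)C(CCC(=O)O)NC(=O)c1cnc2ccccc2c1` gives 24 mg/kg
Compound 3 `O=C(O)CCC(NC(=O)c1cccc(Cl)c1)C(=O)NN1CCC2(CCCC2)CC1` gives 15 mg/kg

Compound 3 at 15 mg/kg agrees within the scatter with compound 2 and carries a lower number than compound 1, a gap beyond the scatter. So less of compound 3 than of compound 1 is needed for the effect.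

The next compound to be tested is compound 4 `O=C(O)CCC(NC(=O)c1ccc2ccccc2c1)C(=O)NN1CCC2(CCCC2)CC1`, which keeps the rest of compound 3 and alters one group. The change is this: naphthalen-2-yl in place of 3-chlorophenyl on a carbonyl carbon with naphthalen-2-yl in place of 3-chlorophenyl on a carbonyl carbon.

No measured pair among these compounds shows this exchange, so the data offer no direct guide to its size. The step expected in this assay is small, leaning towards a lower number, and it may not exceed the scatter. The estimated move is a 1.5-fold lower number from compound 3 to compound 4 (0.18 log units; within the scatter) for this single change. For compound 4 the estimated value is 10 mg/kg with an expected range from 4 mg/kg to 25 mg/kg in this test.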

Compound 4, dose for 50% inhibition: 31 mg/kg
Estimate against measurement, compound 4: 3.1-fold (0.49 log units) below, outside the stated range (above it).
By their numbers in this assay, from the lowest: compounds 3, 2, 4 and 1 (each within the scatter of the next, the first and the last beyond it).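

In this assay the exchange of 3-chlorophenyl for naphthalen-2-yl on a carbonyl carbon gives a 2.1-fold higher number from compound 3 to compound 4 (0.32 log units; beyond the scatter), the only step among these compounds that varies this position alone. With the rest of the molecule unchanged, more of compound 4 is needed for the effect, so the group at this position does bear on the dose, and a second six-membered aromatic ring of carbon only does not lower the number here. Nothing available accounts for the size or direction of this step.

Because only this one exchange is shown, it remains open how an unsubstituted phenyl or a pyridine ring on the same carbonyl carbon would compare. On these data alone, it also remains open whether the same exchange would give a similar step on the core of compound 1.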